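A few compounds are considered here, and "the series" means these few. Any claim that something is new, unique, unknown or untested is made for them only; others in the source may bear on it.

Measured so far:
compound 1 `CC(C)[C@H](NC(=O)COc1cccc2ccccc12)C(=O)N[C@@H](CC(=O)O)C(=O)COc1ccc(C#N)cc1`: > 100000 nM
compound 2 `CC(C)[C@H](NC(=O)COc1cccc2ccccc12)C(=O)N[C@@H](CC(=O)O)C(=O)COc1ccc(OC(F)(F)F)cc1`: 29100 nM
compound 3 `CC(C)[C@H](NC(=O)COc1cccc2ccccc12)C(=O)N[C@@H](CC(=O)O)C(=O)COc1ccc(Oc2ccc(C(F)(F)F)cc2)cc1`: 9300 nM

All three share one core and differ only in the aryl group sitting on the oxygen on a saturated carbon. In a functional assay on Jurkat cells (Homo sapiens) (on this read-out higher numbers stand for weaker inhibition and lower numbers for stronger inhibition), compound 2 gives 29100 nM, the higher of the two numbers that are true values. Its nearest neighbour is compound 3, reached by a 3.1-fold lower number from compound 2 to compound 3 (0.50 log units; beyond the scatter). Compound 1 gives no number at all but only a limit of this assay, (the limit of > 100000 nM in this assay, at which 1 of the 3 values shown sits). Starting from compound 1 the steps are an at least 3.4-fold lower number from compound 1 to compound 2 (0.53 log units; beyond the scatter) and an at least 10-fold lower number from compound 1 to compound 3 (1.03 log units; beyond the scatter).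

Compound 4 `CC(C)[C@H](NC(=O)COc1cccc2ccccc12)C(=O)N[C@@H](CC(=O)O)C(=O)COc1ccc(F)c(F)c1` has not yet been measured. The change from compound 2 is 3,4-difluorophenyl in place of 4-(trifluoromethoxy)phenyl on an oxygen on a saturated carbon. Among the compounds with values here, no measured step makes exactly this exchange, but the measured steps all concern this same aryl group and all move the numbers beyond the scatter: trifluoromethoxy in place of cyano lowered the number, and 4-(trifluoromethyl)phenyl in place of trifluoromethyl lowered it again. Compound 4 removes the trifluoromethoxy and brings in 3,4-difluorophenyl, so the expected step is a 1.5-fold higher number from compound 2 to compound 4 (0.19 log units; within the scatter), a modest rise, with a fair chance of no change beyond the scatter. In this assay compound 4 is therefore estimated to give 45000 nM, between 15000 nM and 100000 nM.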

Compound 4, half-maximal inhibitory concentration: > 100000 nM
Compound 4 ended at the assay's limit (the forecaster's own chance of this, stated with the estimate: 30%); middle value at least 2.2-fold (0.34 log units) away from the limit.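

In this assay, replacing the 4-(trifluoromethoxy)phenyl group with 3,4-difluorophenyl gives an at least 3.4-fold higher number from compound 2 to compound 4 (0.53 log units; beyond the scatter) and so takes the series back to the assay's limit. This shows that fluorine alone on this aryl ring does not preserve the measurable inhibition of compound 2, since two fluorine atoms placed directly on the ring give no true value. Among the four compounds, true values appear only for compound 2 and compound 3, whose ring substituents are joined through oxygen, while compound 1 and compound 4 both end at a limit, so the step between those two cannot be read and they sit together here: the limit of > 100000 nM in this assay, at which 2 of the 4 values shown sit.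

The compounds shown leave open whether the oxygen link, the trifluoromethyl unit or the overall size of the substituent matters most, a question that 4-methoxyphenyl and 4-(trifluoromethyl)phenyl groups at this position could help separate. As far as these compounds go, it also remains unknown how an amine or a carboxylic acid on this ring would read out, or how a plain unsubstituted phenyl would compare.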